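Benzyloxy-aryl sulfonamide hydroxamates: variation at the outer ring

This account rests on a few compounds, and the source may have more. Where it says the series, first, only, none or still open, it means among the compounds named here.

Measured so far in an assay on isolated protein for inhibition of matrix metalloproteinase-9 (Homo sapiens), read by fluorescence, with stated times of 4 h, 15 s and 20 min; a higher number here means a weaker inhibitor, a lower number a stronger inhibitor:
compound 1 `O=C(CNS(=O)(=O)c1ccc(OCc2ccc(Br)cc2)cc1)NO` gives 1.4 nM
compound 2 `O=C(CNS(=O)(=O)c1ccc(OCc2ccc(OC(F)(F)F)cc2)cc1)NO` gives 37 nM
compound 3 `O=C(CNS(=O)(=O)c1ccc(OCc2cccc(OC(F)(F)F)c2)cc1)NO` gives 76 nM

Compound 1 gives the lowest number of the three in this assay; the nearest, compound 2, is a 26-fold higher number from compound 1 to compound 2 (1.42 log units; beyond the scatter), a change brought by trifluoromethoxy in place of bromo on an aromatic carbon. Compound 3 gives a number above that of compound 2, so both trifluoromethoxy analogues sit well behind compound 1.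

Compound 4 `O=C(CNS(=O)(=O)c1ccc(OCc2cc(F)cc(F)c2)cc1)NO` is not yet measured. It differs from compound 1 by 3,5-difluorophenyl in place of 4-bromophenyl on a saturated chain carbon bound to an oxygen on an aromatic ring. Among the compounds with values here, no measured step tests this exact change; the one step available shows that replacing bromo at this ring with another group cost a large amount. The step from compound 1 to compound 4 is therefore expected to raise the number, though fluorine is not trifluoromethoxy, so the expected step is an 11-fold higher number from compound 1 to compound 4 (1.03 log units; beyond the scatter) rather than a full repeat of the measured one. Compound 4 is estimated at 15 nM, within 3 nM to 70 nM.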

Compound 4, half-maximal inhibitory concentration: 330 nM
Compound 4: the middle estimate sits 22-fold (1.34 log units) below what was measured; the measured number lies above the stated range.
By their numbers in this assay, from the lowest: compound 1; then compound 2; then compound 3; then compound 4.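

In this assay the exchange of 4-bromophenyl for 3,5-difluorophenyl gives a 240-fold higher number from compound 1 to compound 4 (2.37 log units; beyond the scatter) and so exceeds a 26-fold higher number from compound 1 to compound 2 (1.42 log units; beyond the scatter) as the largest step out of compound 1. A halogen on the outer ring is thus not enough on its own to keep the low number of compound 1, since compound 4 carries fluorine and still loses far more than the trifluoromethoxy exchange did. Nothing on hand explains the size of this step.

The compounds shown leave open whether the loss follows from removing bromo or from adding the two fluorines, as the step changes both at once. Also open, on these data alone, is how the number would respond to chloro, an amine or a carboxylic acid on the outer ring.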